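The compounds below may be only part of what the source reports. "The series", "measured", "known", "first", "only" and "open" are said of these compounds alone.

Measured in a physicochemical assay for lipophilicity; on this read-out lower numbers stand for lower lipophilicity and higher numbers for higher lipophilicity:
- compound 1 `CCCNC(=O)c1cc(C(=O)NC)nn1[C@@H](C)c1ccccc1`: 4.4
- compound 2 `CNC(=O)c1cc(C(=O)N[C@H]2CC[C@H](O)CC2)n([C@@H](C)c2ccccc2)n1`: 2.9

Of these two numbers, compound 2 has the lower, 2.9. Within the data shown here, the only measured step is large: a number 1.50 log units lower from compound 1 to compound 2 (beyond the scatter). It concerns an amide-type nitrogen, so it bears only loosely on compound 3 `CNC(=O)c1cc(C(=O)N[C@H]2CC[C@H](O)CC2)n([C@@H](C)c2ccccc2Cl)n1`, which differs from compound 2 elsewhere: chloro in place of hydrogen on an aromatic carbon. Among the measured compounds shown here, no measured step covers chloro in place of hydrogen on an aromatic carbon. A moderate upward move in this assay is expected, beyond the scatter but smaller than that large step, with an estimated a number 0.60 log units higher from compound 2 to compound 3 (beyond the scatter). For compound 3 the expected value is 3.5, with an estimated range of 3.1 to 3.9.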

Compound 3, distribution coefficient: 3.9
Estimate against measurement, compound 3: 0.40 log units below; measured number inside the range.
By their numbers in this assay, from the lowest: compound 2; then compound 3; then compound 1.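

In this assay chloro in place of hydrogen on the aromatic carbon ortho to a large group gives a number 1.00 log units higher from compound 2 to compound 3 (beyond the scatter) and so shows that a single-atom change on this ring, and not only on an amide-type nitrogen, moves the read-out beyond the scatter. The 4-hydroxycyclohexyl amide stays the same across this step, so the move belongs to the chloro alone. Nothing on hand explains the size of the step. On these data alone, whether fluoro, methyl or methoxy in this place would move the number likewise stays open. So does whether chloro gives a similar step with the propyl amide of compound 1.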